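This account rests on a few compounds, and the source may have more. Where it says the series, first, only, none or still open, it means among the compounds named here.

Measured in an assay on Cerebral cortex for displacement of a labelled ligand from adenosine receptor A1 (Bos taurus); on this read-out lower numbers stand for stronger inhibition and higher numbers for weaker inhibition:

compound 1, `Fc1ccccc1Cn1nnc2c(NC3CC3)nc(-c3ccccc3)nc21`, gives 15 nM
compound 2, `FC(F)(F)c1ccccc1Cn1nnc2c(NC3CC3)nc(-c3ccccc3)nc21`, gives 7.8 nM
compound 3, `Fc1ccccc1Cn1nnc2c(NC3CCCCC3)nc(-c3ccccc3)nc21`, gives 1.15 nM

Compound 4, `FC(F)(F)c1ccccc1Cn1nnc2c(NC3CCCCC3)nc(-c3ccccc3)nc21`, has not yet been measured in this assay.

The three measured compounds share one core. Compound 1 and compound 2 differ by trifluoromethyl in place of fluoro on an aromatic carbon, and this change gave a 1.9-fold lower number from compound 1 to compound 2 (0.28 log units; within the scatter). Compound 1 and compound 3 differ by cyclohexyl in place of cyclopropyl on a nitrogen on an aromatic ring, and that change gave a 13-fold lower number from compound 1 to compound 3 (1.12 log units; beyond the scatter). Compound 3 thus stands with the lowest number of the three, with the steps to compound 1 and compound 2 both beyond the scatter.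

Compound 4 differs from compound 3 by trifluoromethyl in place of fluoro on an aromatic carbon. This is the same change that separates compound 1 from compound 2: the group that leaves, the group that enters and the place where it sits are described in the same words for both pairs. Within the data shown here, the only measured example of this change is the step from compound 1 to compound 2, which stayed within the scatter. Compound 4 combines this change with the cyclohexylamino group of compound 3.

For compound 4 in this assay the expected step is a 1.6-fold lower number from compound 3 to compound 4 (0.22 log units; within the scatter), resting on the step of a 1.9-fold lower number from compound 1 to compound 2 (0.28 log units; within the scatter) seen when the same change was made on the other core. The estimate for compound 4 is therefore 0.7 nM, expected to fall between 0.25 nM and 2 nM.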

Compound 4, inhibition constant: 6.8 nM
The estimate for compound 4 lay 9.7-fold (0.99 log units) below the measured number; measured number outside the range, above it.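

In this assay, trifluoromethyl in place of fluoro gave a 5.9-fold higher number from compound 3 to compound 4 (0.77 log units; beyond the scatter), so on the core of compound 3 this change did not behave as it had on the core of compound 1: the same change on two cores in this assay, a 1.9-fold lower number (0.28 log units; within the scatter) from compound 1 to compound 2 and a 5.9-fold higher number (0.77 log units; beyond the scatter) from compound 3 to compound 4, 11-fold (1.06 log units) apart, beyond the scatter of two such steps

Seen from the other direction, cyclohexyl in place of cyclopropyl gave a 1.1-fold lower number from compound 2 to compound 4 (0.06 log units; within the scatter), so the large gain that this swap brought with fluoro present did not appear with trifluoromethyl present: the same change on two cores in this assay, a 13-fold lower number (1.12 log units; beyond the scatter) from compound 1 to compound 3 and a 1.1-fold lower number (0.06 log units; within the scatter) from compound 2 to compound 4, 11-fold (1.06 log units) apart, beyond the scatter of two such steps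

Together these show that, in this series, the effect of either change depends on what sits at the other place, so a step measured on one core could not simply be added to another; but they rest on a single set of four compounds and do not show why the two changes interact or how either would behave on any further core.

The compounds shown leave open whether the same dependence would appear with other groups in place of fluoro, such as chloro, methyl or methoxy, or with other groups on the nitrogen, such as cyclobutyl or cyclopentyl. They also leave open how a plain benzyl, with no group on its ring, would fit alongside these four.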